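Para-substituted aryl acids: nitro in place of methoxy

The source may hold more compounds than are shown below. What is called first, only, known or untested is meant among the compounds shown, and "the series" means these compounds.

In a functional assay on NCI-H460 cells (Homo sapiens) for inhibition, read by sulforhodamine B assay, with a stated time of 48 h (a higher number here means a weaker inhibitor of growth, a lower number a stronger inhibitor of growth), the three measured values are all limits:
compound 1 `CC(C)(C)NCc1c(C(=O)O)nn(-c2ccccc2)c1-c1ccc(F)cc1` limit > 680000 nM
compound 2 `CC(C)(C)NCc1c(C(=O)O)nn(-c2ccccc2)c1-c1ccccc1` limit > 716000 nM
compound 3 `COc1ccc(-c2c(CNC(C)(C)C)c(C(=O)O)nn2-c2ccccc2)cc1` limit > 659000 nM

Compound 3 holds only a limit (> 659000 nM) in this assay and has no exact number. Compound 4 `CC(C)(C)NCc1c(C(=O)O)nn(-c2ccccc2)c1-c1ccc([N+](=O)[O-])cc1` carries nitro in place of methoxy on an aromatic carbon, para to a large group (nitro in place of methoxy on an aromatic carbon). Within the data shown here, three measured steps bear on this same place: hydrogen in place of fluoro (a step that the two limits leave unreadable from compound 1 to compound 2), methoxy in place of fluoro (a step that the two limits leave unreadable from compound 1 to compound 3) and methoxy in place of hydrogen (a step that the two limits leave unreadable from compound 2 to compound 3). None of them has a readable size, and none involves nitro. From these steps, no step beyond the scatter is expected in this assay and no direction can be given. Another limit is the most likely report. The expected step is small (an at least 1.0-fold lower number from compound 3 to compound 4 (0.02 log units; that floor lies within the scatter)). For compound 4 the estimate is 620000 nM (expected range 250000 nM to 750000 nM).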

Compound 4, concentration for 50% growth inhibition: > 634000 nM
Compound 4 gave a limit, no number; the forecaster's own chance of this, stated with the estimate: 80%; middle value at least 1.0-fold (0.00 log units) away from the limit.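

In this assay compound 4 gives only a limit, > 634000 nM, so its steps to compound 1, compound 2 and compound 3 cannot be read. The compounds shown leave open whether fluoro, hydrogen, methoxy or nitro at this place differ in growth inhibition at all.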